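Two methyl groups on the nitrogen arm of compound 1

The source may report more compounds than this note shows. Statements on the series, on what has been measured and on what is new or still open speak of the compounds shown alone.

Measured so far:
compound 1, `Cc1ccccc1-c1nnc(NN)s1`, in a functional assay on the whole organism with Mus musculus as the target, in the maximal electroshock model, with a stated time of 1 h; a lower number here means that less compound is needed, a higher number that more compound is needed for the effect: > 100 mg/kg
compound 2, `Cc1ccccc1-c1nnc(N(N)Cc2ccccc2)s1`: 27 mg/kg

Compound 1 sits at the edge of what this assay reports: its value of > 100 mg/kg is a limit, not a number (the limit of > 100 mg/kg in this assay, at which 1 of the 2 values shown sits). Among the measured compounds shown here, the one measured step, an at least 3.7-fold lower number from compound 1 to compound 2 (0.56 log units; beyond the scatter), shows that putting a carbon group on that nitrogen brings the number down to where a value can be read. Compound 3, `CNN(C)c1nnc(-c2ccccc2C)s1`, makes a related change: methyl(methylamino)amino in place of aminoamino on an aromatic carbon. Both steps replace hydrogen on the nitrogen arm with carbon, so the measured step points the direction, though the entering groups here are smaller than benzyl. A move in the same direction, but of modest size, is therefore expected. For compound 3 the estimate is 60 mg/kg, with a range from 25 mg/kg to 150 mg/kg, which would mean an at least 1.6-fold lower number from compound 1 to compound 3 (0.22 log units; that floor lies within the scatter).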

Compound 3, dose for half-maximal effect: 10 mg/kg
For compound 3 the middle estimate is 6.0-fold (0.78 log units) above the measured one; measured number outside the range, below it.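

The change to methyl(methylamino)amino on this aromatic carbon gives an at least 10-fold lower number from compound 1 to compound 3 (1.00 log units; beyond the scatter), so a readable number at this position does not depend on a benzyl group or on any ring in the entering group. Among the compounds shown, compound 2 reads 27 mg/kg with carbon on one nitrogen of the arm, and compound 3 reads 10 mg/kg with carbon on both. From the compounds shown here alone, the true size of the step stays unknown, since the value for compound 1 is only a limit: the limit of > 100 mg/kg in this assay, at which 1 of the 3 values shown sits.

The compounds shown leave open which of the two methyl groups accounts for the step, as neither stands alone on the arm here. They also leave open how an ethyl group, a longer chain or an acetyl group on either nitrogen would read in this assay.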